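Ethyl in place of fluoro on the fused ring of compound 2

A few compounds are considered here, and "the series" means these few. Any claim that something is new, unique, unknown or untested is made for them only; others in the source may bear on it.

Compound 2 `CCn1c(=O)/c(=C2\Sc3cc(F)ccc3N2C)s/c1=C\c1ccncc1Nc1ccccc1F` carries a fluoro on an aromatic carbon of its fused ring system, where compound 1 `CCn1c(=O)/c(=C2\Sc3ccccc3N2C)s/c1=C\c1ccncc1Nc1ccccc1F` carries hydrogen. In a functional assay on PC-3 cells (Homo sapiens) for inhibition (on this read-out lower numbers stand for stronger inhibition and higher numbers for weaker inhibition), compound 1 gives 360 nM and compound 2 gives 260 nM. For the measured compounds named here, the only measured step, a 1.4-fold lower number from compound 1 to compound 2 (0.14 log units; within the scatter), leaves compound 2 with the lowest of the two numbers, but its gap to compound 1 is within the scatter, so the two compounds cannot be ordered.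

Compound 3 `CCc1ccc2c(c1)S/C(=c1/s/c(=C\c3ccncc3Nc3ccccc3F)n(CC)c1=O)N2C` arises from compound 2 by the change (ethyl in place of fluoro on an aromatic carbon), that is ethyl in place of fluoro on an aromatic carbon. The step from compound 1 to compound 2 bears on this only loosely: it exchanged hydrogen for fluoro at the same aromatic carbon and stayed within the scatter, whereas here ethyl replaces the fluoro. Going by the values given here, no measured step speaks to ethyl at that place, so there is no ground to expect a shift beyond the scatter in this assay in either direction. Compound 3 is therefore expected to give about 350 nM, within a range from 120 nM to 1000 nM, which corresponds to an expected step of a 1.3-fold higher number from compound 2 to compound 3 (0.13 log units; within the scatter).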

Compound 3, half-maximal inhibitory concentration: 2200 nM
Compound 3: the middle estimate sits 6.3-fold (0.80 log units) below what was measured; the measured number lies above the stated range.
By their numbers in this assay, from the lowest: compounds 2 and 1 (each within the scatter of the next); then compound 3.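

The aromatic carbon where hydrogen and fluoro could not be told apart does respond to what it carries: in this assay, ethyl in place of fluoro gives an 8.5-fold higher number from compound 2 to compound 3 (0.93 log units; beyond the scatter), and ethyl in place of hydrogen gives a 6.1-fold higher number from compound 1 to compound 3 (0.79 log units; beyond the scatter). Both steps lie beyond the scatter and point the same way, toward weaker inhibition, so the result does not depend on which of the two smaller substituents serves as the point of comparison. Nothing available gives a reason for this loss of inhibition.

The three compounds do not tell whether the loss belongs to ethyl alone or would also follow with methyl, methoxy or a longer chain such as propyl on this carbon. They also leave open whether an amine or a carboxylic acid there would stay close to compound 2 at 260 nM or fall nearer to compound 3 at 2200 nM.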